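The compounds below may be only part of what the source reports. "The series", "measured", "known", "first", "only" and "open" are said of these compounds alone.

Values measured so far in a physicochemical assay for lipophilicity; a higher number here means a more lipophilic compound, a lower number a more polar compound:

- compound 1 `COc1ccc(C2=NO[C@]3(C2)C(=O)O[C@@H]2[C@H]3CC[C@H](C)[C@]3(O)C=CC(=O)[C@@]23C)cc1`: 1.47
- compound 2 `C[C@H]1CC[C@@H]2[C@@H](OC(=O)[C@]23CC(c2ccc(Cl)cc2)=NO3)[C@]2(C)C(=O)C=C[C@@]12O`: 2.09
- compound 3 `C[C@H]1CC[C@@H]2[C@@H](OC(=O)[C@]23CC(c2ccc(N(C)C)cc2)=NO3)[C@]2(C)C(=O)C=C[C@@]12O`: 1.51

The three compounds share a core and differ only in one group on the aromatic ring. The two steps into compound 3 are a number 0.04 log units higher from compound 1 to compound 3 (within the scatter) and a number 0.58 log units lower from compound 2 to compound 3 (beyond the scatter). Compound 3 therefore stands level with compound 1 and under compound 2.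

The next compound is compound 4 `C[C@H]1CC[C@@H]2[C@@H](OC(=O)[C@]23CC(c2cccc([N+](=O)[O-])c2)=NO3)[C@]2(C)C(=O)C=C[C@@]12O`, with 3-nitrophenyl in place of 4-(dimethylamino)phenyl on a carbon with a double bond to nitrogen.

Among the compounds with values here, no measured compound carries a nitro group, so the evidence is indirect. Two of the measured swaps on the ring moved the number modestly, a number 0.62 log units higher from compound 1 to compound 2 (beyond the scatter) and the step from chloro to dimethylamino already given, and both involve chloro. The swap without chloro stayed within the scatter. In this assay, no step beyond the scatter is therefore the best guess, though a modest one in either direction remains possible. The expected step is a number 0.01 log units lower from compound 3 to compound 4 (within the scatter). Compound 4 is estimated at 1.5, with an expected range from 1.15 to 1.9.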

Compound 4, partition coefficient: 1.37
Estimate against measurement, compound 4: 0.13 log units above; low and high end bracket the measured number.
By their numbers in this assay, from the lowest: compounds 4, 1 and 3 (each within the scatter of the next); then compound 2.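

In this assay, the 3-nitrophenyl group on this carbon with a double bond to nitrogen gives a number level with both 4-(dimethylamino)phenyl and 4-methoxyphenyl, at a number 0.14 log units lower from compound 3 to compound 4 (within the scatter) and a number 0.10 log units lower from compound 1 to compound 4 (within the scatter). The 4-chlorophenyl compound now stands apart from three different groups rather than two, with the new step being a number 0.72 log units lower from compound 2 to compound 4 (beyond the scatter). Nothing measured on these compounds accounts for this grouping.

On these data alone, it remains open whether a carboxylic acid, a primary amine or a bromo group on the aromatic ring would stay with compounds 1, 3 and 4 or move towards compound 2. The compounds shown also leave open how the number responds to changes elsewhere on the shared core, as all of them differ only in this one group.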